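The source may hold more compounds than are shown below. What is called first, only, known or untested is meant among the compounds shown, and "the series" means these compounds.

Measured so far:
- compound 1, `CC(C)OC(=O)N1CCC(Oc2cccc3c2CCN3c2ccc(S(C)(=O)=O)cc2F)CC1`: 62%
- compound 2, `CC(C)(C)OC(=O)N1CCC(Oc2ncnc3c2CCN3c2ccc(S(C)(=O)=O)cc2F)CC1`: 139%

Of the compounds shown here, two have been tested in a functional assay on CHO-K1 cells with Glucose-dependent insulinotropic receptor (Homo sapiens) as the target, read by a luciferase reporter, with a stated time of 5 h; on this read-out lower numbers stand for smaller maximal responses and higher numbers for larger maximal responses. Compound 1 gives 62%, while compound 2 gives 139%. Compound 2 thus stands highest of the two, and its gap to compound 1 lies beyond the usual scatter; the two differ in more than one place, so the gap cannot be tied to a single change.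

Compound 3, `CC(C)COC(=O)N1CCC(Oc2ncnc3c2CCN3c2ccc(S(C)(=O)=O)cc2F)CC1`, keeps the core of compound 2 and alters only the carbamate end: isobutyl in place of tert-butyl on an oxygen next to a carbonyl group. Both groups carry the same atoms, joined differently, and neither adds a ring, a donor or an acceptor.

Among the compounds with values here, no single-change step between measured compounds is available, so the size of this step is uncertain. Compound 3 is expected to stay close to compound 2, with at most a modest loss in this assay. The estimated step of a number 19 percentage points lower from compound 2 to compound 3 (beyond the scatter) is small. Compound 3 is therefore estimated at 120%, within a range from 80% to 160%.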

Compound 3, largest response reached (reported as percent of maximum), in percent of the reference or control that the assay uses: 94%
Beside the measured number, compound 3's estimate is 26 percentage points above it; the measured number falls inside the stated range.
By their numbers in this assay, from the lowest: compound 1; then compound 3; then compound 2.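

Within the data shown here, this is the first change that can be read at a single place. Isobutyl in place of tert-butyl on an oxygen next to a carbonyl group gives a number 45 percentage points lower from compound 2 to compound 3 (beyond the scatter) in this assay and counts as a large step. Both groups have the same atoms, joined differently, and the rest of the molecule stays the same, so rearranging the carbon atoms at this end alone is enough to change the maximal response. The data shown offer no measured explanation for the size of this step.

As far as these compounds go, it remains open how a straight butyl chain or a cyclobutyl ring at this place would compare with tert-butyl and isobutyl. Compound 1 differs from compound 3 in more than one place, so the separate contributions of the core and the carbamate end also remain unresolved.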